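A few compounds are considered here, and "the series" means these few. Any claim that something is new, unique, unknown or untested is made for them only; others in the source may bear on it.

Compound 1 `CCCN1CCn2cc(C(=O)OC(C)C(C)(C)C)c(C)c2C1=O` carries a plain propyl chain on its ring nitrogen, and in a functional assay on CHO cells for inhibition of metabotropic glutamate receptor 1 (Rattus norvegicus) (a higher number here means a weaker inhibitor, a lower number a stronger inhibitor), compound 1 gives 39.8 nM. Compound 2 `CCNC(=O)NCCCN1CCn2cc(C(=O)OC(C)C(C)(C)C)c(C)c2C1=O` extends that chain with a urea group, and in this assay compound 2 gives 398 nM. Among the measured compounds shown here, the step of a 10-fold higher number from compound 1 to compound 2 (1.00 log units; beyond the scatter) is therefore a clear loss of inhibitory strength, and among the two measured numbers compound 2 holds the highest one, with compound 1 as its only neighbour. Compound 3 `CC(=O)NCCCN1CCn2cc(C(=O)OC(C)C(C)(C)C)c(C)c2C1=O` keeps the chain of compound 2 but changes its end: methyl in place of ethylamino on a carbonyl carbon. For the measured compounds named here, the only measured step that bears on this position is the one from compound 1 to compound 2, where attaching the whole urea cost a modest amount. Removing part of that group while keeping the amide could recover some of this loss, so for compound 3 a step of a 1.6-fold lower number from compound 2 to compound 3 (0.20 log units; within the scatter) toward a somewhat lower number is expected, giving an estimated 250 nM within a range from 80 nM to 800 nM.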

Compound 3, half-maximal inhibitory concentration: 501 nM
For compound 3 the middle estimate is 2.0-fold (0.30 log units) below the measured one; low and high end bracket the measured number.
By their numbers in this assay, from the lowest: compound 1; then compounds 2 and 3 (each within the scatter of the next).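

In this assay, putting methyl in place of ethylamino on the carbonyl carbon gives a 1.3-fold higher number from compound 2 to compound 3 (0.10 log units; within the scatter), so compound 2 and compound 3 cannot be told apart, although the ethylamino group carries a hydrogen-bond donor and methyl carries none. The larger change lies in adding the group to the chain at all: acetamido in place of hydrogen gives a 13-fold higher number from compound 1 to compound 3 (1.10 log units; beyond the scatter), in line with the step already seen for the longer urea group. Nothing measured here explains why either group weakens inhibition.

On these data alone, it remains open which part of the added group matters, the carbonyl or the nitrogen on the chain. A plain amine, a carboxylic acid or a longer hydrocarbon chain at this position could help to separate those parts.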